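A methoxy group added to compound 3

This account rests on a few compounds, and the source may have more. Where it says the series, first, only, none or still open, it means among the compounds named here.

compound 1 `O=C(CC(CC(=O)c1cccc(Br)c1)c1cccnc1)c1cccc(Br)c1`: 181000 nM
compound 2 `O=C(/C=C/c1ccccc1)c1cccc(Br)c1`: 18400 nM
compound 3 `O=C(/C=C/c1cccnc1)c1ccccc1`: 7700 nM

All three numbers come from an ADME assay on KB cells (Homo sapiens) for cytotoxicity, read by resazurin assay, with a stated time of 72 h; on this read-out higher numbers stand for weaker inhibition and lower numbers for stronger inhibition. Compound 3 gives the lowest of them, 7700 nM. Compound 2 gives 18400 nM, a gap beyond the usual scatter, and compound 1 lies furthest away at 181000 nM, also beyond the scatter.

Compound 4 `COc1cccc(C(=O)/C=C/c2cccnc2)c1` is compound 3 with methoxy in place of hydrogen on an aromatic carbon, meta to a large group: methoxy in place of hydrogen on an aromatic carbon. Going by the values given here, no two measured compounds differ in just one place, so the data give no direct reading of this change in this assay. Starting from compound 3 at 7700 nM, no step beyond the scatter is expected, and neither direction is favoured. The expected size is a 1.0-fold higher number from compound 3 to compound 4 (0.02 log units; within the scatter). For compound 4 the estimated value is 8000 nM, with an expected range of 3000 nM to 25000 nM.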

Compound 4, half-maximal inhibitory concentration: 2300 nM
Beside the measured number, compound 4's estimate is 3.5-fold (0.54 log units) above it; measured number outside the range, below it.
By their numbers in this assay, from the lowest: compound 4; then compound 3; then compound 2; then compound 1.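

Within this assay methoxy in place of hydrogen on an aromatic carbon, meta to a large group, brings a 3.3-fold lower number from compound 3 to compound 4 (0.52 log units; beyond the scatter) and this is the first direct reading of a single change among these compounds. It shows that this place on the ring is not silent: swapping a hydrogen atom for a group of 2 heavy atoms moves the number towards stronger inhibition, by more than the usual scatter. Nothing available explains why the number falls.

Still open, from the compounds shown here alone, is whether the gain belongs to methoxy itself, since one step cannot show how another group, such as an amine, a hydroxyl or a longer chain like ethoxy, would behave here. Equally open, going by these compounds, is whether methoxy would bring a similar step from another carbon of the same ring.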